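The source may hold more compounds than are shown below. What is called first, only, known or untested is meant among the compounds shown, and "the series" means these compounds.

Compound 1 `COc1ccc(N(C)c2ncnc3c2ncn3Cc2cc(OC)c(OC)c(OC)c2)cc1` gives > 100000 nM, which is a limit of the assay and not a number.
Compound 2 `COc1ccc(N(C)c2nc(Cl)nc3c2ncn3Cc2cc(OC)c(OC)c(OC)c2)cc1` gives 85000 nM.
Compound 3 `COc1cc(Cn2cnc3c(Cl)ncnc32)cc(OC)c1` gives > 100000 nM, again a limit of the assay rather than a number.

All three were tested in a functional assay on AGS cells (Homo sapiens) for antiproliferative activity, read by MTT assay, with a stated time of 48 h; a higher number here means a weaker inhibitor of growth, a lower number a stronger inhibitor of growth. Compound 1 and compound 2 differ by chloro in place of hydrogen on an aromatic carbon, which gave an at least 1.1-fold lower number from compound 1 to compound 2 (0.07 log units; that floor lies within the scatter). Compound 3 has a different core from compound 1, and the difference of the two cores is not broken down here. The same kind of change turns compound 3 into compound 4 `COc1cc(Cn2cnc3c(Cl)nc(Cl)nc32)cc(OC)c1`: chloro in place of hydrogen on an aromatic carbon. The surroundings are not identical, the entering chloro being meta to a chloro group rather than meta to a (4-methoxyphenyl)(methyl)amino group. Compound 4 is expected to show only a small step, a number no higher from compound 3 to compound 4 (the limit leaves the size open), because an at least 1.1-fold lower number from compound 1 to compound 2 (0.07 log units; that floor lies within the scatter) barely moved this assay and because the limit of > 100000 nM in this assay, at which 2 of the 3 values shown sit, already holds compound 3. The estimate for compound 4 is 100000 nM, from 40000 nM to 300000 nM.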

Compound 4, concentration for 50% growth inhibition: 3800 nM
Beside the measured number, compound 4's estimate is 26-fold (1.42 log units) above it, outside the stated range (below it).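

In this assay, chloro in place of hydrogen on an aromatic carbon gave an at least 26-fold lower number from compound 3 to compound 4 (1.42 log units; beyond the scatter), a large drop on the core of compound 3. This does not show that the change works differently on the core of compound 1, since the two steps cannot be told apart: the same change on two cores in this assay, an at least 1.1-fold lower number (0.07 log units; that floor lies within the scatter) from compound 1 to compound 2 and an at least 26-fold lower number (1.42 log units; beyond the scatter) from compound 3 to compound 4; the limit leaves it open whether they differ. Both steps start from a limit of the assay and not from a number, so neither step has a known full size: the limit of > 100000 nM in this assay, at which 2 of the 4 values shown sit.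

The compounds shown leave open whether chloro is special at this place between two ring nitrogen atoms, or whether bromo, fluoro or an amine there would give a similar drop. They also leave open how the change behaves on a core whose starting compound gives a measurable number.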